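Cytotoxicity on liver cells: benzyl replaces difluorophenyl

A few compounds are considered here, and "the series" means these few. Any claim that something is new, unique, unknown or untested is made for them only; others in the source may bear on it.

This account follows a small series of amines built on a shared core and tested in an ADME assay on Huh-7 cells (Homo sapiens) for cytotoxicity; on this read-out higher numbers stand for lower toxicity in this test and lower numbers for higher toxicity in this test. Compound 1 `CN1CCN(CCCNCc2cn(-c3ccc(C(F)(F)F)cc3)nc2-c2ccc(C(F)(F)F)cc2)CC1` gives 2000 nM in this assay. Compound 3 `CCCN1CCC(CNCc2cn(-c3ccc([N+](=O)[O-])cc3)nc2-c2ccc(C(F)(F)F)cc2)CC1` gives 2300 nM in this assay, a value within the usual scatter of compound 1. Compound 2 `Cc1ccccc1-c1nn(-c2cc(F)ccc2F)cc1CNCCN1CCN(C)CC1` stands apart: in this assay compound 2 reaches only a limit, > 20000 nM, and no number is known for it. That limit is the limit of > 20000 nM in this assay, at which 1 of the 3 values shown sits, and marks compound 2 as the least toxic of the three measured compounds on the numbers shown, though the size of its gap to compounds 1 and 3 cannot be fixed.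

Compound 4 `Cc1ccccc1-c1nn(Cc2ccccc2)cc1CNCCN1CCN(C)CC1` has not yet been measured in this assay. It differs from compound 2 in one place: benzyl in place of 2,5-difluorophenyl on an aromatic nitrogen. The pieces that leave and enter are both single aromatic rings of carbon, neither carrying donors, acceptors or charge, so the author expects no step beyond the scatter from compound 2 to compound 4, and the expected step of an at least 1.1-fold lower number from compound 2 to compound 4 (0.04 log units; that floor lies within the scatter) is accordingly small. For compound 4 the author therefore estimates 18000 nM in this assay, with a range from 6000 nM to 50000 nM, and a real chance that the assay again reports only a limit.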

Compound 4, half-maximal cytotoxic concentration: > 20000 nM
Compound 4: no number, only a limit; the forecaster's own chance of this, stated with the estimate: 45%; middle value at least 1.1-fold (0.04 log units) from the limit.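

Compound 2 and compound 4 both stop at the same limit in this assay, so no step between them can be read: the limit of > 20000 nM in this assay, at which 2 of the 4 values shown sit.

The compounds shown leave open what actual numbers lie behind these limits, and whether benzyl in place of 2,5-difluorophenyl on an aromatic nitrogen shifts the result in this assay at all.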